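Removing the ring-amine methyl in a second series

The source may hold more compounds than are shown below. What is called first, only, known or untested is meant among the compounds shown, and "the series" means these compounds.

Compound 1 `c1ccc2c(c1)ccn2-c1nc(N2CCNCC2)nc2ccccc12`: 8.9 ug/mL in an ADME assay on Vero cells (Chlorocebus sabaeus) for antiproliferative activity, read by MTT assay; a lower number here means a stronger inhibitor, a higher number a weaker inhibitor
Compound 2 `CN1CCN(c2nc(-n3ccc4ccccc43)c3ccccc3n2)CC1`: 22.3 ug/mL in this assay
Compound 3 `COc1cc(OC)c(-c2nc(N3CCN(C)CC3)nc3ccccc23)c(OC)c1`: 50 ug/mL in this assay

Compound 3 has the highest number of the three in this assay. How the core of compound 3 differs from that of compound 2 is not broken down here. Between compound 2 and compound 1 the only change is hydrogen in place of methyl on an amine nitrogen in a ring, and it gave a 2.5-fold lower number from compound 2 to compound 1 (0.40 log units; beyond the scatter).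

Compound 4 `COc1cc(OC)c(-c2nc(N3CCNCC3)nc3ccccc23)c(OC)c1` is not yet measured in this assay. It is compound 3 with hydrogen in place of methyl on an amine nitrogen in a ring, the same change at the same place, seen twice among these compounds. For the measured compounds named here, the step from compound 3 to compound 4 is expected to be a 2.5-fold lower number from compound 3 to compound 4 (0.40 log units; beyond the scatter) because a 2.5-fold lower number from compound 2 to compound 1 (0.40 log units; beyond the scatter) is the single precedent for this change. Compound 4 is therefore estimated at 20 ug/mL, with a likely range from 9 ug/mL to 45 ug/mL.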

Compound 4, half-maximal inhibitory concentration: 50 ug/mL
Estimate against measurement, compound 4: 2.5-fold (0.40 log units) below, and the stated range ends below it.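

In this assay, going from 4-methylpiperazin-1-yl to piperazin-1-yl gave no change at the digits printed from compound 3 to compound 4 (within the scatter), so the step seen on the core of compound 2 did not reappear as a measurable change on the core of compound 3. Set side by side, the two steps cannot be told apart: the same change on two cores in this assay, a 2.5-fold lower number (0.40 log units; beyond the scatter) from compound 2 to compound 1 and no change at the digits printed (within the scatter) from compound 3 to compound 4, 2.5-fold (0.40 log units) apart, within the scatter of two such steps. The pair therefore does not show that the change carries over from one core to the other, nor that the core alters its size, and one step per core supports no rule for the series.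

The compounds shown leave open how an ethyl group, a longer chain or an acetyl group on that amine nitrogen would compare on either core. They also leave open how the same change would behave on a third core.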